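A few compounds are considered here, and "the series" means these few. Any claim that something is new, unique, unknown or untested is made for them only; others in the source may bear on it.

Working notes on the series. Among the compounds with values here, compound 2 `O=[N+]([O-])c1ccc(N/C(=N\O)c2ccc(F)cc2)c2nonc12` gives the lower of the two numbers so far in an assay on isolated protein for inhibition of Indoleamine 2,3-dioxygenase 1 (Homo sapiens), read by spectrophotometry, with a stated time of 1 h (a higher number here means a weaker inhibitor, a lower number a stronger inhibitor), namely 100 nM. Compound 1 `O=[N+]([O-])c1ccc(N/C(=N\O)c2ccccc2)c2nonc12` gives 268 nM in this assay. Within the data shown here, the one measured step is a 2.7-fold lower number from compound 1 to compound 2 (0.43 log units; beyond the scatter).

Compound 3 `O=[N+]([O-])c1ccc(N/C(=N\O)c2ccc(Cl)cc2)c2nonc12` differs from compound 2 by chloro in place of fluoro on an aromatic carbon, that is 4-fluorophenyl to 4-chlorophenyl. Among the measured compounds shown here, no measured step exchanges one of these groups for the other; the only step in hand, from hydrogen to fluoro, went to a lower number, and it bears on this change only as a hint that the site tolerates a group there. The expected step of a 1.2-fold lower number from compound 2 to compound 3 (0.07 log units; within the scatter) in this assay is therefore small, likely within the scatter, with the direction uncertain. Compound 3 is thus estimated at 85 nM, with a range from 35 nM to 220 nM.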

Compound 3, half-maximal inhibitory concentration: 113 nM
Compound 3: the middle estimate sits 1.3-fold (0.12 log units) below what was measured, within the range that was stated.
By their numbers in this assay, from the lowest: compounds 2 and 3 (each within the scatter of the next); then compound 1.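

In this assay the step from fluoro to chloro is a 1.1-fold higher number from compound 2 to compound 3 (0.05 log units; within the scatter) and so gives no order between the two halogens at this position on the phenyl ring. With chloro in place of hydrogen there is a 2.4-fold lower number from compound 1 to compound 3 (0.38 log units; beyond the scatter) and thus a lower number than with hydrogen now rests on two different halogens on this aromatic carbon, not on fluoro alone. Nothing to hand gives a reason for either step.

The compounds shown leave open whether this holds for groups other than these halogens at the same place, such as bromo, methoxy, an amine or a carboxylic acid. They also leave open whether any such group would separate from fluoro and chloro by more than the scatter, in either direction.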